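Swapping a Saturated Ring for Benzyl on the Core

The source may hold more compounds than are shown below. What is called first, only, known or untested is meant among the compounds shown, and "the series" means these compounds.

Compound 1 `Cc1cc(NC(=O)Cn2nnc(-c3ccccc3)n2)n(C2CCC(C)(C)CC2)n1` carries a 4,4-dimethylcyclohexyl group on an aromatic nitrogen of its core. In an assay on HEK293 cells for activation of Kir3.1/Kir3.2 (Homo sapiens), read by thallium flux (on this read-out lower numbers stand for an effect already at smaller amounts and higher numbers for an effect only at larger amounts of compound), compound 1 gives only a limit of the measurement, > 221 nM, and not a number. This limit, (the limit of > 221 nM in this assay, at which 1 of the 2 values shown sits), is where one of the two recorded results sits, so compound 1 stands at the weak end of what has been seen. Compound 2 `Cc1nc(-c2ccccc2)c(NC(=O)Cn2nnc(-c3ccccc3)n2)s1` has a different core, and in this assay compound 2 is recorded as "not active" (no number reported), again without a number. Compound 3 `Cc1cc(NC(=O)Cn2nnc(-c3ccccc3)n2)n(Cc2ccccc2)n1` is the untested partner of compound 1; the change is benzyl in place of 4,4-dimethylcyclohexyl on an aromatic nitrogen. Among the compounds with values here, no pair of measured compounds shows what this swap does, so there is no measured step to lean on. Because compound 1 gives > 221 nM in this assay, the expectation is that compound 3 also acts only at larger amounts. The step that the limit leaves unreadable from compound 1 to compound 3 is expected to stay within the usual scatter. Compound 3 is therefore estimated at 3000 nM, within a range from 400 nM to 20000 nM, with a fair chance that only a limit is reported again.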

Compound 3, half-maximal effective concentration: 495 nM
Compound 3: middle estimate off by 6.1-fold (0.78 log units), on the high side, within the range that was stated.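

The step from compound 1 to compound 3, benzyl in place of 4,4-dimethylcyclohexyl, cannot be read, because compound 1 has only a limit and not a number: the limit of > 221 nM in this assay, at which 1 of the 3 values shown sits. The compounds shown leave open how large this swap on the shared core really is, and in which direction it moves the result.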